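The source may hold more compounds than are shown below. What is called first, only, known or untested is meant among the compounds shown, and "the series" means these compounds.

Going by the values given here, compound 1 `CCOC(=O)c1cc([Se]Cc2ccccc2)c2cc(OC)ccc2n1` gives 20800 nM in a functional assay on Jurkat cells (Homo sapiens) for cytotoxicity, read by MTT assay, with a stated time of 24 h (on this read-out lower numbers stand for an effect already at smaller amounts and higher numbers for an effect only at larger amounts of compound), the lower of the two numbers measured so far. Among the compounds with values here, compound 2 `CCOC(=O)c1cc([Se]Cc2ccccc2)c2cc(Br)ccc2n1` gives 53600 nM in this assay, and the one measured step, a 2.6-fold higher number from compound 1 to compound 2 (0.41 log units; beyond the scatter), concerns bromo in place of methoxy on an aromatic carbon rather than the group on selenium. Compound 3 `CCOC(=O)c1cc([Se]c2ccccc2)c2cc(OC)ccc2n1` differs from compound 1 by phenyl in place of benzyl on a selenium. Within the data shown here, no measured step bears on this change, so for compound 3 only a step within the scatter is expected, namely no change at the digits printed from compound 1 to compound 3 (within the scatter). Compound 3 is therefore estimated at 20800 nM, with a range from 7000 nM to 60000 nM.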

Compound 3, half-maximal effective concentration: 102000 nM
Compound 3: the middle estimate sits 4.9-fold (0.69 log units) below what was measured; measured number outside the range, above it.
By their numbers in this assay, from the lowest: compound 1; then compounds 2 and 3 (each within the scatter of the next).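

The group on selenium proves to matter on its own: with the methoxy kept, phenyl in place of benzyl in this assay gives a 4.9-fold higher number from compound 1 to compound 3 (0.69 log units; beyond the scatter). Among these compounds, benzyl therefore gives the lower number at this position. Nothing available here explains this step.

As far as these compounds go, whether a longer chain on selenium, such as phenylethyl, or a group carrying an amine would lower the number further remains open. So does whether phenyl in place of benzyl has a similar effect on the bromo compound, compound 2.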